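Swapping a Styryl Arm for a Biaryl Arm

This account rests on a few compounds, and the source may have more. Where it says the series, first, only, none or still open, it means among the compounds named here.

Measured compounds:
Compound 1, `CC(C)(C)OC(=O)/C=C/c1ccc(CN(C(=O)C2CCCCC2)c2cccc(/C=C/C(=O)OC(C)(C)C)c2)cc1`, gives 1000 nM in an assay on isolated protein with Bile acid receptor (Homo sapiens) as the target; on this read-out lower numbers stand for an effect already at smaller amounts and higher numbers for an effect only at larger amounts of compound.
Compound 2, `COC(=O)/C=C/c1cccc(N(Cc2ccc(/C=C/C(=O)OC(C)(C)C)cc2O)C(=O)C2CCCCC2)c1`, gives 1000 nM in this assay.
Compound 3, `COC(=O)/C=C/c1cccc(N(Cc2ccc(/C=C/c3c(Cl)cccc3Cl)cc2)C(=O)C2CCCCC2)c1`, gives 151 nM in this assay.

Among these three, compound 3 stands out with the lowest number, and its gap to compound 1 and its gap to compound 2 are both beyond the usual scatter of repeated measurements, so compound 3 is the most potent of the measured set in this assay.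

The unmeasured compound 4, `COC(=O)/C=C/c1cccc(N(Cc2ccc(-c3cc(Cl)ccc3OC)cc2)C(=O)C2CCCCC2)c1`, differs from compound 3 in a single place: 5-chloro-2-methoxyphenyl in place of 2-(2,6-dichlorophenyl)ethenyl on an aromatic carbon. The arm that links the shared core to the outer ring loses its double bond, and the outer ring itself is changed.

Among the compounds with values here, no measured pair in this set shares that change, so its size cannot be read from the data. Within the data shown here, the expectation rests only on the fact that compound 3 is the one with the lowest number and that a change of this kind is more likely to loosen than to tighten the effect. A step from compound 3 to compound 4 of a 2.3-fold higher number from compound 3 to compound 4 (0.37 log units; beyond the scatter) is expected, toward a higher number but of modest size. For compound 4 the estimate in this assay is 350 nM, with a range from 90 nM to 1500 nM.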

Compound 4, half-maximal effective concentration: 234 nM
Estimate against measurement, compound 4: 1.5-fold (0.17 log units) above; measured number inside the range.
By their numbers in this assay, from the lowest: compounds 3 and 4 (each within the scatter of the next); then compounds 1 and 2 (each within the scatter of the next).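

In this assay, putting 5-chloro-2-methoxyphenyl in place of 2-(2,6-dichlorophenyl)ethenyl gives a 1.5-fold higher number from compound 3 to compound 4 (0.19 log units; within the scatter) and so leaves the two arms indistinguishable on this read-out. Within the data shown here, the earlier compounds included no pair differing in one place, so this is the first direct reading at this position, on an aromatic carbon para to a large group. In this single pair, an outer ring attached directly, without the double bond, and carrying one chlorine and a methoxy group instead of two chlorines, gives a number within the scatter of the original, although no measured evidence here explains this result.

The compounds shown leave open which part of the change matters, as the loss of the double bond and the new outer ring arrive together, and a compound keeping the ethenyl link while carrying the 5-chloro-2-methoxyphenyl ring would separate the two. Also open, going by these compounds, is how this position responds to a different kind of group on the outer ring, such as a primary amine or a carboxylic acid.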